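From 4-chlorophenoxy to 4-nitrophenoxy: working notes

A few compounds are considered here, and "the series" means these few. Any claim that something is new, unique, unknown or untested is made for them only; others in the source may bear on it.

In a functional assay on RAW264.7 cells (Mus musculus), read by ELISA, with stated times of 1 h and 24 h (on this read-out lower numbers stand for stronger inhibition and higher numbers for weaker inhibition), compound 1 `CN1CCN(CCCCCOc2cccc(N3C(=O)S/C(=C\c4ccc(Oc5ccc(F)cc5)cc4)C3=O)c2)CC1` reads > 10000 nM, which is a limit of the assay. Within the data shown here, compound 2 `CN1CCN(CCCCCOc2cccc(N3C(=O)S/C(=C\c4ccc(Oc5ccc(Cl)cc5)cc4)C3=O)c2)CC1` gives 8520 nM, the only actual number so far. Compound 3 `CN1CCN(CCCCCOc2cccc(N3C(=O)S/C(=C\c4ccc(Oc5ccc([N+](=O)[O-])cc5)cc4)C3=O)c2)CC1` carries nitro in place of chloro on an aromatic carbon, para to a large group (nitro in place of chloro on an aromatic carbon). Among the measured compounds shown here, the sole measured guide is chloro in place of fluoro, an at least 1.1-fold lower number from compound 1 to compound 2 (0.06 log units; that floor lies within the scatter), and it rests on (the limit of > 10000 nM in this assay, at which 1 of the 2 values shown sits). That gives no ground for a large shift in either direction, so the expected change is a 1.1-fold higher number from compound 2 to compound 3 (0.02 log units; within the scatter), with no step beyond the scatter. For compound 3 the estimated value is 9000 nM, with an expected range of 3500 nM to 20000 nM.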

Compound 3, half-maximal inhibitory concentration: > 10000 nM
Compound 3: a limit, no number; the forecaster's own chance of this, stated with the estimate: 40%; middle value at least 1.1-fold (0.04 log units) from the limit.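

At this position, nitro in place of chloro gives an at least 1.1-fold higher number from compound 2 to compound 3 (0.06 log units; that floor lies within the scatter) in this assay. On these data alone, compound 3 reads > 10000 nM, which is a limit, so the true size of that step stays unknown. The step from compound 1 to compound 3 cannot be read, and the series still rests on a single actual number: the limit of > 10000 nM in this assay, at which 2 of the 3 values shown sit.

Open, as far as these compounds go, is whether any group on this aromatic carbon brings the read-out clearly away from the limit. An amine, a carboxylic acid or a methoxy group there would test this.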